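Tert-butoxy for dimethylamino: a step starting from a limit

The source may hold more compounds than are shown below. What is called first, only, known or untested is meant among the compounds shown, and "the series" means these compounds.

In an ADME assay on Huh-7 cells (Homo sapiens) for cytotoxicity, with a stated time of 72 h (on this read-out higher numbers stand for lower toxicity in this test and lower numbers for higher toxicity in this test), three compounds with a shared core have been read so far. Compound 1 (`Cc1cn([C@@H]2O[C@H](CO[Si](C)(C)C(C)(C)C)[C@@]3(OS(=O)(=O)C=C3N)[C@H]2O[Si](C)(C)C(C)(C)C)c(=O)n(C(=O)CCCBr)c1=O`) gives > 100000 nM as a limit of the assay. Compound 2 (`Cc1cn([C@@H]2O[C@H](CO[Si](C)(C)C(C)(C)C)[C@@]3(OS(=O)(=O)C=C3N)[C@H]2O[Si](C)(C)C(C)(C)C)c(=O)n(C(=O)C2CC2)c1=O`) gives > 100000 nM as a limit as well. Compound 3 (`Cc1cn([C@@H]2O[C@H](CO[Si](C)(C)C(C)(C)C)[C@@]3(OS(=O)(=O)C=C3N)[C@H]2O[Si](C)(C)C(C)(C)C)c(=O)n(C(=O)CCCC(=O)N(C)C)c1=O`) also gives > 100000 nM as a limit, so it has no number of its own and stands level with the other two (the limit of > 100000 nM in this assay, at which 3 of the 3 values shown sit).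

Compound 4 (`Cc1cn([C@@H]2O[C@H](CO[Si](C)(C)C(C)(C)C)[C@@]3(OS(=O)(=O)C=C3N)[C@H]2O[Si](C)(C)C(C)(C)C)c(=O)n(C(=O)CCCC(=O)OC(C)(C)C)c1=O`) carries tert-butoxy in place of dimethylamino on a carbonyl carbon, which also reads as dimethylcarbamoyl to tert-butoxycarbonyl.

Three measured changes bear on this, and none has a size. They are a step that the two limits leave unreadable from compound 1 to compound 3 for dimethylcarbamoyl in place of bromo, a step that the two limits leave unreadable from compound 2 to compound 3 for 3-(dimethylcarbamoyl)propyl in place of cyclopropyl, and a step that the two limits leave unreadable from compound 1 to compound 2 for cyclopropyl in place of 3-bromopropyl. The expectation therefore has one anchor, compound 3 at > 100000 nM as a limit. The estimated change is a number no higher from compound 3 to compound 4 (the limit leaves the size open) and no direction is expected, with nothing foreseen beyond the usual scatter. Compound 4 is estimated at 100000 nM with an expected range from 60000 nM to 150000 nM and the assay is expected to report a limit once more.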

Compound 4, half-maximal cytotoxic concentration: > 100000 nM
Compound 4 was reported as a limit; the forecaster's own chance of this, stated with the estimate: 90%; the middle value lies on the limit itself.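

In this assay compound 4 gives > 100000 nM, which is a limit. No new step can be read from compound 1, compound 2 or compound 3 to compound 4, since all four sit together: the limit of > 100000 nM in this assay, at which 4 of the 4 values shown sit.

The compounds shown leave open what value any of the four actually has, and so whether any of these changes alters the read-out at all.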